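Sulfonyl aryl variation on the shared core: nitro to 4-methylphenyl

The source may hold more compounds than are shown below. What is called first, only, known or untested is meant among the compounds shown, and "the series" means these compounds.

Two compounds of the series share one core and differ only in the aryl on the sulfonyl sulfur. Compound 1 `COc1cc2nc(N3CCN(S(=O)(=O)c4ccc([N+](=O)[O-])cc4)CC3)nc(N)c2cc1OC` gives 36000 nM in a functional assay on PC-3 cells (Homo sapiens) for inhibition; a lower number here means a stronger inhibitor, a higher number a weaker inhibitor. Compound 2 `COc1cc2nc(N3CCN(S(=O)(=O)c4cc(Cl)ccc4Cl)CC3)nc(N)c2cc1OC` gives 60000 nM in this assay. Compound 1 has the lowest of the two numbers; its nearest neighbour is compound 2, and the step of a 1.7-fold higher number from compound 1 to compound 2 (0.22 log units; within the scatter) lies within the scatter.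

Compound 3 `COc1cc2nc(N3CCN(S(=O)(=O)c4ccc(-c5ccc(C)cc5)cc4)CC3)nc(N)c2cc1OC` is not yet measured. It differs from compound 1 as follows: 4-methylphenyl in place of nitro on an aromatic carbon.

Within the data shown here, only the step from compound 1 to compound 2 bears on this change, since it also exchanges the aryl on the sulfonyl sulfur, and it gave a 1.7-fold higher number from compound 1 to compound 2 (0.22 log units; within the scatter). That one exchange moved the number no further than the scatter, so for compound 3 no step beyond the scatter is expected in this assay, in either direction. Compound 3 is therefore estimated at 30000 nM, with a range from 8000 nM to 100000 nM, which corresponds to an expected step of a 1.2-fold lower number from compound 1 to compound 3 (0.08 log units; within the scatter).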

Compound 3, half-maximal inhibitory concentration: 3400 nM
Estimate against measurement, compound 3: 8.8-fold (0.95 log units) above, and the stated range ends above it.
By their numbers in this assay, from the lowest: compound 3; then compounds 1 and 2 (each within the scatter of the next).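

In this assay, the aromatic carbon para to a large group proves sensitive to what it carries: 4-methylphenyl in place of nitro gives an 11-fold lower number from compound 1 to compound 3 (1.02 log units; beyond the scatter), whereas the earlier exchange of the whole aryl, a 1.7-fold higher number from compound 1 to compound 2 (0.22 log units; within the scatter), stayed within the scatter. The change swaps nitro, with 3 heavy atoms and no ring, for 4-methylphenyl, with 7 heavy atoms and one six-membered aromatic ring, so added size and an added ring arrive together and this one pair cannot separate them. No measurement at hand speaks to the reason for this step.

From the compounds shown here alone, whether the lower number needs the second aromatic ring or its methyl remains open, and a plain phenyl or a hexyl chain at this place would bear on that. Also open, going by these compounds, is how an amine or a carboxylic acid on the added ring would behave.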